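A few compounds are considered here, and "the series" means these few. Any claim that something is new, unique, unknown or untested is made for them only; others in the source may bear on it.

Compound 1 `COC[C@H](C(C)C)C(c1ccc(O)c(OC)c1)c1ccc(O)c(OC)c1`: 72000 nM
Compound 2 `COc1ccc(C(c2ccc(OC)c(OC)c2)[C@H](C)[C@@H](C)CO)cc1OC`: 47000 nM
Compound 3 `COc1ccc(C(c2ccc(OC)c(OC)c2)[C@H](C)[C@H](C)CO)cc1OC`: a limit only, > 100000 nM

All three were tested in a functional assay on HL-60 cells (Homo sapiens) for cytotoxicity, read by WST assay, with a stated time of 48 h; a higher number here means a weaker inhibitor, a lower number a stronger inhibitor. Compound 1 gives 72000 nM in this assay, the higher of the two plain numbers, yet compound 2 with 47000 nM sits within the usual scatter of it, so the two cannot be told apart. For compound 3 the measurement stopped at a limit, > 100000 nM. Going by the values given here, the single step that can be counted is an at least 2.1-fold higher number from compound 2 to compound 3 (0.32 log units; beyond the scatter); it is a step between two compounds that differ only in configuration (the fact that compounds 2 and 3 differ only in the configuration as drawn), and its size is capped by the limit of > 100000 nM in this assay, at which 1 of the 3 values shown sits.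

Compound 4 `COc1cc(C(c2ccc(O)c(OC)c2)[C@H](CC(C)C)C(C)C)ccc1O` differs from compound 1 by isopropyl in place of methoxy on a saturated chain carbon, three bonds along the chain from two aromatic carbons. Among the compounds with values here, no measured step touches an exchange of this kind: the one step in hand concerns configuration alone and says nothing about swapping a methoxy for an isopropyl on that saturated chain carbon. With nothing to point either way, compound 4 is expected to stay close to compound 1. The estimate for compound 4 is 70000 nM, within a range from 25000 nM to 200000 nM. This expectation amounts to a 1.0-fold lower number from compound 1 to compound 4 (0.01 log units; within the scatter), a step not expected to exceed the scatter.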

Compound 4, half-maximal inhibitory concentration: 9600 nM
Compound 4: middle estimate off by 7.3-fold (0.86 log units), on the high side; measured number below the stated range.
By their numbers in this assay, from the lowest: compound 4; then compounds 2 and 1 (each within the scatter of the next). At a limit, above all of these: compound 3.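

In this assay, the exchange of methoxy for isopropyl on a saturated chain carbon, three bonds along the chain from two aromatic carbons, gives a 7.5-fold lower number from compound 1 to compound 4 (0.88 log units; beyond the scatter). Going by these compounds alone, this shows that the group at this place can move the number beyond the scatter, whereas the only earlier step, between compound 2 and compound 3, concerned configuration alone; the same exchange can also be read, one bond further out, as methoxymethyl to isobutyl. Nothing given here accounts for the size or direction of this step.

Only this one exchange at this place is shown, so a single pair cannot tell whether losing the methoxy or gaining the isopropyl matters more. From the compounds shown here alone, how an ethyl, a longer chain such as hexyl, or an amine at the same carbon would read in this assay remains open.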